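The compounds below may be only part of what the source reports. "The series", "measured", "known", "first", "only" and "open" are said of these compounds alone.

Of the compounds shown here, three have so far been measured in a functional assay on NIH3T3 cells for agonist activity at Urotensin-2 receptor (Homo sapiens), with a stated time of 5 days; on this read-out lower numbers stand for smaller maximal responses and higher numbers for larger maximal responses. Compound 1 `Cc1ccc(C(CCN(C)C)NC(=O)CCc2ccccc2)cc1` gives 73%, compound 2 `COc1ccc(/C=C/C(=O)NC(CCN(C)C)c2ccc(Cl)cc2)cc1` gives 99%, and compound 3 `CN(C)CCC(NC(=O)CCc1ccccc1)c1ccc(Cl)cc1` gives 139%, the highest of the three numbers. Among the measured compounds shown here, the only single-site step measured, a number 66 percentage points higher from compound 1 to compound 3 (beyond the scatter), came from a chloro in place of methyl on an aromatic carbon. Compound 4 `CN(C)CCC(NC(=O)/C=C/c1ccccc1)c1ccc(Cl)cc1` keeps that chloro and differs from compound 3 only in 2-phenylethenyl in place of phenethyl on a carbonyl carbon. For the measured compounds named here, no measured step isolates this change, so the chloro step does not speak to it; compound 2, which also carries a double bond outside aromatic rings but differs from compound 3 in a second place as well, sits well below compound 3. A moderate drop is therefore expected, a number 29 percentage points lower from compound 3 to compound 4 (beyond the scatter). Compound 4 is estimated at 110%, within 80% to 140%.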

Compound 4, largest response reached (reported as efficacy), in percent of the reference or control that the assay uses: 128%
The estimate for compound 4 lay 18 percentage points below the measured number, and the stated range covers the measured number.
By their numbers in this assay, from the lowest: compound 1; then compound 2; then compound 4; then compound 3.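

In this assay the double bond that 2-phenylethenyl brings onto the carbonyl carbon costs little, with a number 11 percentage points lower from compound 3 to compound 4 (beyond the scatter) as a modest step, so a high maximal response does not depend on the saturated phenethyl. Hydrogen in place of methoxy on an aromatic carbon gives a number 29 percentage points higher from compound 2 to compound 4 (beyond the scatter) as a second modest step, so the lower number of compound 2 goes with its methoxy as well as its double bond. Nothing available explains either step. Still open, going by these compounds, is how a longer chain in place of phenethyl would read, or a fluoro or an amine in place of that hydrogen.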